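The source may report more compounds than this note shows. Statements on the series, on what has been measured and on what is new or still open speak of the compounds shown alone.

Three compounds have numbers in a functional assay on SF-295 cells (Homo sapiens) (on this read-out lower numbers stand for stronger inhibition of growth and higher numbers for weaker inhibition of growth), so far:

compound 1, `COc1ccc(-c2cc(O)c3cccnc3n2)cc1`, gives 64600 nM;
compound 2, `Oc1cc(-c2ccc(Cl)cc2)nc2ncccc12`, gives 40700 nM;
compound 3, `Cc1cnc2nc(-c3ccc(Cl)cc3)cc(O)c2c1`, gives 2400 nM.

The two cores of compound 2 and compound 3 differ by methyl in place of hydrogen on an aromatic carbon, and that change made a 17-fold lower number from compound 2 to compound 3 (1.23 log units; beyond the scatter). From compound 2 to compound 1 the change is methoxy in place of chloro on an aromatic carbon, and it made a 1.6-fold higher number from compound 2 to compound 1 (0.20 log units; within the scatter).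

Compound 4, `COc1ccc(-c2cc(O)c3cc(C)cnc3n2)cc1`, has not been measured. It carries the same change from compound 3, (methoxy in place of chloro on an aromatic carbon), which occurs twice among these compounds. The step from compound 3 to compound 4 is expected to be a 1.6-fold higher number from compound 3 to compound 4 (0.20 log units; within the scatter), because a 1.6-fold higher number from compound 2 to compound 1 (0.20 log units; within the scatter) was the earlier outcome of this change. On that basis compound 4 is estimated to give about 3800 nM in this assay, with a likely range from 1500 nM to 12000 nM.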

Compound 4, concentration for 50% growth inhibition: 5250 nM
Beside the measured number, compound 4's estimate is 1.4-fold (0.14 log units) below it, within the range that was stated.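

In this assay, methoxy in place of chloro gave a 2.2-fold higher number from compound 3 to compound 4 (0.34 log units; beyond the scatter), and its two outcomes agree across the two cores: the same change on two cores in this assay, a 1.6-fold higher number (0.20 log units; within the scatter) from compound 2 to compound 1 and a 2.2-fold higher number (0.34 log units; beyond the scatter) from compound 3 to compound 4, 1.4-fold (0.14 log units) apart, within the scatter of two such steps. Methyl in place of hydrogen on an aromatic carbon gave a 12-fold lower number from compound 1 to compound 4 (1.09 log units; beyond the scatter), and this change also carried over from one core to the other: the same change on two cores in this assay, a 17-fold lower number (1.23 log units; beyond the scatter) from compound 2 to compound 3 and a 12-fold lower number (1.09 log units; beyond the scatter) from compound 1 to compound 4, 1.4-fold (0.14 log units) apart, within the scatter of two such steps. Going by these compounds alone, both changes therefore held between these two cores in this one read-out, but with only two steps for each change, this does not show that they would hold on any other core.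

The compounds shown leave open what an amine or a carboxylic acid would give in place of the chloro or methoxy group. They also leave open what a longer chain would give in place of the methyl group.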